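Selenium to sulfur swap on the bis-furoyl isothiourea scaffold

The source may report more compounds than this note shows. Statements on the series, on what has been measured and on what is new or still open speak of the compounds shown alone.

Three compounds of the series carry two aromatic carboxamide arms on a central carbon with a double bond to nitrogen, and differ in the arms and in the chalcogen group on that carbon. Compound 1 `C[Se]/C(=N\C(=O)c1cc2ccccc2s1)NC(=O)c1cc2ccccc2s1` gives 65600 nM in a functional assay on PC-3 cells (Homo sapiens) for cytotoxicity, read by MTT assay, with a stated time of 72 h; a lower number here means a stronger inhibitor of growth, a higher number a weaker inhibitor of growth. Compound 3 `C[Se]/C(=N\C(=O)c1ccco1)NC(=O)c1ccco1` gives 56700 nM in this assay, the lowest of the two numbers shown, though compound 1 sits within the scatter of it. Compound 2 `CS/C(=N\C(=O)c1ccno1)NC(=O)c1ccno1` reaches only the limit of this assay, > 100000 nM, which is a limit and not a number; one of the three results sits at this limit (the limit of > 100000 nM in this assay, at which 1 of the 3 values shown sits).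

Compound 4 `CS/C(=N\C(=O)c1ccco1)NC(=O)c1ccco1` is the untested partner of compound 3, differing by a group of 2 heavy atoms (1 carbon, 1 sulfur; no ring) in place of a group of 2 heavy atoms (1 carbon, 1 selenium; no ring), on a carbon with a double bond to nitrogen. For the measured compounds named here, no measured pair isolates this change, so the direction is uncertain; compound 2 carries the same methylsulfanyl group on other arms and is a limit. The expected step of a 1.6-fold higher number from compound 3 to compound 4 (0.20 log units; within the scatter) is a modest loss, possibly beyond the scatter. Compound 4 is estimated at 90000 nM, between 45000 nM and 180000 nM, with a real chance of a limit only.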

Compound 4, concentration for total growth inhibition: > 100000 nM
Compound 4 was reported as a limit; the forecaster's own chance of this, stated with the estimate: 40%; at least 1.1-fold (0.04 log units) between middle value and limit.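

With the arms held constant, methylsulfanyl in place of the selenium-bearing group on a carbon with a double bond to nitrogen now has its first measured pair in this assay: an at least 1.7-fold higher number from compound 3 to compound 4 (0.24 log units; that floor lies within the scatter). Compound 4 is a limit, so only a floor is known for this step, and that floor does not separate the pair from the scatter. The two methylsulfanyl compounds shown, compound 2 and compound 4, both sit at the limit of the assay: the limit of > 100000 nM in this assay, at which 2 of the 4 values shown sit.

On these data alone, whether the same swap on the arms of compound 1 would give a step of similar direction stays open. Also open, as far as these compounds go, is what an amine, or a longer chain carried on selenium, would give on this same carbon, and whether the number of compound 3 depends on selenium itself.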